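Repositioning the oxolane oxygen in an EZH2 inhibitor series

The compounds below may be only part of what the source reports. "The series", "measured", "known", "first", "only" and "open" are said of these compounds alone.

Measured compounds:
- compound 1, `Cc1cc(C)c(CN2CCc3c(Cl)cc([C@H](CO)[C@H]4CCOC4)c(Cl)c3C2=O)c(=O)[nH]1`: 10 nM
- compound 2, `Cc1cc(C)c(CN2CCc3c(Cl)cc(C(CO)c4ccon4)c(Cl)c3C2=O)c(=O)[nH]1`: 7960 nM; 273 nM (2 entries)

Going by the values given here, compound 1 is the only compound here with a single number in an assay on cells for inhibition of histone-lysine N-methyltransferase EZH2 (Homo sapiens), read by ELISA, with a stated time of 72 h; a lower number here means a stronger inhibitor, a higher number a weaker inhibitor; compound 1 gives 10 nM, and it also has one further entry without a single number. Compound 2 sits far from it in this assay, with 7960 nM; 273 nM (2 entries); the two entries for compound 2 disagree widely, as shown by the several entries of compound 2 in this assay, 7960 nM; 273 nM (2 entries), so compound 2 offers little footing for what follows. Among the compounds with values here, no single-point step between measured compounds is available.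

Compound 3, `Cc1cc(C)c(CN2CCc3c(Cl)cc([C@H](CO)[C@@H]4CCCO4)c(Cl)c3C2=O)c(=O)[nH]1`, is the unmeasured compound. It differs from compound 1 by oxolan-2-yl in place of oxolan-3-yl on a saturated chain carbon bound to an aromatic carbon and a saturated chain carbon. The same atoms are joined differently, and the defined stereocentre is kept.

Within the data shown here, with no measured step of this kind, a modest move toward weaker inhibition is expected, near the edge of the scatter; the estimated step of a 3.0-fold higher number from compound 1 to compound 3 (0.48 log units; beyond the scatter) reflects that. For compound 3 the expected value in this assay is 30 nM, within 8 nM to 150 nM.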

Compound 3, half-maximal inhibitory concentration: 41 nM
Beside the measured number, compound 3's estimate is 1.4-fold (0.14 log units) below it, and the stated range covers the measured number.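

In this assay, oxolan-2-yl in place of oxolan-3-yl on a saturated chain carbon bound to an aromatic carbon and a saturated chain carbon gives a 4.1-fold higher number from compound 1 to compound 3 (0.61 log units; beyond the scatter). Going by these compounds alone, this is the first single-place step at this position, and it shows that the read-out responds to how the ring is joined, since the two groups carry the same heavy atoms and the same count of hydrogen-bond acceptors, yet the loss is modest and compound 3 still gives 41 nM. Nothing in the data shown bears on why the joining of the ring changes the number.

The compounds shown leave open how much of this step belongs to the placing of the ring oxygen and how much to the new stereocentre, as only one defined form of the oxolan-2-yl compound appears here. They also leave open whether the ring oxygen is needed at all, a question that a cyclopentyl group at the same place would address, while an oxan-4-yl group would test a larger ring carrying the same hetero atom.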